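Working notes: chloro in place of methyl from compound 2

This account rests on a few compounds, and the source may have more. Where it says the series, first, only, none or still open, it means among the compounds named here.

Measured in an ADME assay on the whole organism (Mus musculus, strain CD1) for pharmacokinetics, at a dose of 10 mg/kg by the oral route; on this read-out higher numbers stand for higher oral bioavailability and lower numbers for lower oral bioavailability:
- compound 1 `COc1cc(N2C(=O)C3(CCC3)N(c3ccc(OC4CCN(C)CC4)nc3)C2=S)cnc1C#N` (116%)
- compound 2 `Cc1cc(N2C(=O)C3(CCC3)N(c3ccc(OC4CCNCC4)nc3)C2=S)cnc1C#N` (92%)

Compound 2 (92%) holds the lower of the two values. Compound 1 (116%) lies higher, and the gap is beyond the usual scatter. These two compounds differ in more than one place, so their gap cannot be assigned to any single change.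

Compound 3 `N#Cc1ncc(N2C(=O)C3(CCC3)N(c3ccc(OC4CCNCC4)nc3)C2=S)cc1Cl` is still unmeasured and departs from compound 2 in one place (chloro in place of methyl on an aromatic carbon). This is chloro in place of methyl on an aromatic carbon, ortho to a cyano group, turning 6-cyano-5-methylpyridin-3-yl into 5-chloro-6-cyanopyridin-3-yl. For the measured compounds named here, no measured pair isolates this change, so the expectation stays anchored on compound 2 (92%). In this assay the expected step is small, slightly downward and within the scatter (a number 4 percentage points lower from compound 2 to compound 3 (within the scatter)). For compound 3 the estimated value is 88% (expected range 65% to 110%).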

Compound 3, oral bioavailability: 118%
Compound 3: middle estimate off by 30 percentage points, on the low side; measured number above the stated range.
By their numbers in this assay, from the lowest: compound 2; then compounds 1 and 3 (each within the scatter of the next).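

In this assay, for the compounds shown here, chloro in place of methyl on an aromatic carbon, ortho to a cyano group, gives a number 26 percentage points higher from compound 2 to compound 3 (beyond the scatter), the first change that can be read at a single place. The earlier pair differed in more than one place and could assign nothing to this position, whereas this pair shows that the group here can by itself move oral bioavailability beyond the scatter, with 6-cyano-5-methylpyridin-3-yl giving the lower number and 5-chloro-6-cyanopyridin-3-yl the higher. No measured property of these compounds bears on the origin of this step.

The compounds shown leave open whether the rise is particular to chloro or would also appear with fluoro, bromo, trifluoromethyl or methoxy at this same place on an otherwise unchanged compound. Going by these compounds alone, they also leave open whether the same exchange gives a similar step when the rest of the molecule differs, since it rests on the single pair of compound 2 and compound 3.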